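A few compounds are considered here, and "the series" means these few. Any claim that something is new, unique, unknown or untested is made for them only; others in the source may bear on it.

Within the data shown here, in a functional assay on SV5A8 cells (Homo sapiens) for cytotoxicity (a higher number here means a weaker inhibitor, a lower number a stronger inhibitor), every compound so far has reached only the limit of the assay. Compound 1 `Cc1ccc2c(NCc3ccc(NC(=O)C4CCN(Cc5ccccc5)CC4)cc3)nc(N(C)CCCN(C)C)nc2c1` gives > 8620 nM, a limit rather than a number. Compound 2 `Cc1ccc2c(NCc3ccc(NC(=O)C4CCN(Cc5ccccc5)CC4)cc3)nc(N(C)CCN(C)C)nc2c1` gives > 8830 nM, likewise a limit. Compound 3 `Cc1ccc2c(NCc3ccc(NC(=O)C4CCN(CC5CCNCC5)CC4)cc3)nc(N(C)C)nc2c1` gives > 8070 nM, again a limit and no number, so compound 3 stands where the other two stand, at the edge of what this assay reports. Among the measured compounds shown here, the one measured step, a step that the two limits leave unreadable from compound 1 to compound 2, cannot be read between two limits, so no step of known size bears on the change to compound 4 `Cc1ccc(CN2CCC(C(=O)Nc3ccc(CNc4nc(N(C)C)nc5cc(C)ccc45)cc3)CC2)cc1`. That change is 4-methylphenyl in place of piperidin-4-yl on a saturated chain carbon bound to an amine nitrogen in a ring. Nothing measured speaks to this change, so compound 4 is expected to stay near the limit and the step that the limit leaves unreadable from compound 3 to compound 4 is estimated to be essentially none. Compound 4 is estimated at 10000 nM, with a range from 4000 nM to 30000 nM.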

Compound 4, half-maximal inhibitory concentration: > 4150 nM
Compound 4 gave a limit, no number (the forecaster's own chance of this, stated with the estimate: 80%); the middle value does not contradict the limit.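

Compound 3 and compound 4 both end at a limit in this assay, not at a number, so no step can be read between them. The compounds shown leave open whether any such change yields a measurable value.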